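The compounds below may be only part of what the source reports. "The series", "measured", "known", "first", "only" and "open" are said of these compounds alone.

Working notes on the nitrobenzylidene series in a functional assay on HPLF cells (Homo sapiens) for cytotoxicity; a higher number here means that more compound is tolerated, a lower number that less compound is tolerated. Three compounds carry measured numbers. Compound 1, `COc1cc(/C=C2\CC/C(=C\c3ccc([N+](=O)[O-])cc3)C2=O)cc(OC)c1OC`, sits at the limit of this assay: for compound 1 the value reads > 400000 nM, a limit and not a number, as noted in the limit of > 400000 nM in this assay, at which 1 of the 3 values shown sits. Compound 3, `COc1ccc(/C=C2\CCC/C(=C\c3ccc([N+](=O)[O-])cc3)C2=O)cc1OC`, gives 95000 nM. Compound 2, `COc1cc(/C=C2\Cc3ccccc3/C(=C\c3ccc([N+](=O)[O-])cc3)C2=O)ccc1O`, gives 21000 nM, the lowest of the two numbers shown, with compound 3 the nearest at a gap beyond the scatter. No pair among these three differs in a single place, so no measured step is available within this set.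

The next compound, compound 4, `COc1ccc(/C=C2\Cc3ccccc3/C(=C\c3ccc([N+](=O)[O-])cc3)C2=O)cc1OC`, differs from compound 2 in one place: methyl in place of hydrogen on an oxygen on an aromatic ring, hydroxy to methoxy, 4-hydroxy-3-methoxyphenyl to 3,4-dimethoxyphenyl. Within the data shown here, no measured step speaks to this change, so the expectation is a step of no size beyond the scatter in this assay, in either direction. The expected step is a 1.4-fold higher number from compound 2 to compound 4 (0.15 log units; within the scatter). Compound 4 is therefore estimated at 30000 nM, with a range from 10000 nM to 100000 nM.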

Compound 4, half-maximal cytotoxic concentration: > 400000 nM
Compound 4: no number, only a limit; the forecaster's own chance of this, stated with the estimate: 10%; middle value at least 13-fold (1.12 log units) away from the limit.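

In this assay, among these compounds, the first single-place step is large: hydroxy to methoxy, methyl in place of hydrogen on an oxygen on an aromatic ring, gives an at least 19-fold higher number from compound 2 to compound 4 (1.27 log units; beyond the scatter). This shows that the change from 4-hydroxy-3-methoxyphenyl to 3,4-dimethoxyphenyl is not neutral on this core, and that the compound with the free hydroxy is the one tolerated at the lower concentration in this pair. The value of compound 4 is a limit and not a number: the limit of > 400000 nM in this assay, at which 2 of the 4 values shown sit.

On these data alone, the size of the step beyond that limit stays open, as does whether an ethyl group on the same oxygen, or an amine in place of the hydroxy, would read like compound 2 or like compound 4. Among the compounds shown here, only one pair speaks to this change, so its reach to other cores also remains open.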